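The source may report more compounds than this note shows. Statements on the series, on what has been measured and on what is new or still open speak of the compounds shown alone.

Going by the values given here, in a functional assay on COLO 205 cells (Homo sapiens) for inhibition, read by sulforhodamine B assay (on this read-out higher numbers stand for weaker inhibition of growth and lower numbers for stronger inhibition of growth), two compounds built on the same core have numbers so far. Compound 1 `COc1ccc(-c2ccc(-c3ccc(-c4nc5cc(C)ccc5[nH]4)cc3)cc2)cc1OC` gives 2320 nM, and compound 2 `Cc1ccc2[nH]c(-c3ccc(-c4ccc(-c5ccc(OC(F)(F)F)cc5)cc4)cc3)nc2c1` gives 30600 nM, the higher of the two, which makes compound 2 the weaker growth inhibitor of the pair.

Among the compounds with values here, the one measured step, a 13-fold higher number from compound 1 to compound 2 (1.12 log units; beyond the scatter), put 4-(trifluoromethoxy)phenyl in place of 3,4-dimethoxyphenyl on an aromatic carbon. Compound 3 `Cc1ccc2[nH]c(-c3ccc(-c4ccc(-c5ccc(O)cc5)cc4)cc3)nc2c1` changes that same group again: hydrogen replaces trifluoromethyl on an oxygen on an aromatic ring (hydrogen in place of trifluoromethyl on an oxygen on an aromatic ring), so trifluoromethoxy becomes hydroxy.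

Within the data shown here, no measured compound carries the hydroxy group, so the evidence is thin. Still, that single step shows how far the number can move when this group changes, and compound 2 sits at the high end. A lower number is therefore expected, by somewhat less than the full size of that step. The estimated change is a 5.1-fold lower number from compound 2 to compound 3 (0.71 log units; beyond the scatter), read in this assay. For compound 3 the expected value is 6000 nM, with an estimated range of 1500 nM to 25000 nM.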

Compound 3, concentration for 50% growth inhibition: 100000 nM
For compound 3 the middle estimate is 17-fold (1.22 log units) below the measured one, and the stated range ends below it.
By their numbers in this assay, from the lowest: compound 1; then compound 2; then compound 3.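

In this assay, the step from trifluoromethoxy to hydroxy does not bring the number back toward that of compound 1: there is a 3.3-fold higher number from compound 2 to compound 3 (0.51 log units; beyond the scatter) even though the change removes the trifluoromethyl group and leaves only a hydrogen on the oxygen. Set against the 3,4-dimethoxyphenyl group, the loss is much larger, with a 43-fold higher number from compound 1 to compound 3 (1.63 log units; beyond the scatter) on replacing that group by 4-hydroxyphenyl, so among these three compounds a free hydroxy gives the weakest growth inhibition and the 3,4-dimethoxyphenyl group the strongest. The data shown include no measurement that could explain this order.

The compounds shown leave open whether a single methoxy group on this ring would give a number as low as that of compound 1, or whether both methoxy groups are needed. How an amine, a carboxylic acid or a longer chain such as ethoxy would compare at this same place also remains an open question.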